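The source may report more compounds than this note shows. Statements on the series, on what has been measured and on what is new or still open speak of the compounds shown alone.

In a functional assay on HeLa cells (Homo sapiens) for cytotoxicity, read by MTT assay (a higher number here means a weaker inhibitor, a lower number a stronger inhibitor), compound 1 `CCOC(=O)C12C(=O)OCC=C1COC2c1ccc(F)cc1` gives 22900 nM, and compound 2 `CCOC(=O)C12C(=O)OCC=C1COC2c1ccc(Cl)cc1` gives 118000 nM, the highest of the two numbers here. For the measured compounds named here, the only measured step, a 5.2-fold higher number from compound 1 to compound 2 (0.71 log units; beyond the scatter), swapped one halogen for another. Compound 3 `CCOC(=O)C12C(=O)OCC=C1COC2c1ccccn1` differs from compound 2 by pyridin-2-yl in place of 4-chlorophenyl on a saturated ring carbon. Going by the values given here, no measured step changes the whole ring, so the chloro-for-fluoro step is only a loose guide. Since the chlorine leaves, the expected step of a 2.6-fold lower number from compound 2 to compound 3 (0.42 log units; beyond the scatter) is a modest fall in the number, but it could easily stay within the scatter. Compound 3 is therefore expected to give about 45000 nM, within 10000 nM to 200000 nM.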

Compound 3, half-maximal inhibitory concentration: 20700 nM
The estimate for compound 3 lay 2.2-fold (0.34 log units) above the measured number, within the range that was stated.
By their numbers in this assay, from the lowest: compounds 3 and 1 (each within the scatter of the next); then compound 2.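

In this assay, this saturated ring carbon does not need a carbon-only aromatic ring: with pyridin-2-yl in place of 4-chlorophenyl there is a 5.7-fold lower number from compound 2 to compound 3 (0.76 log units; beyond the scatter), and with it in place of 4-fluorophenyl there is a 1.1-fold lower number from compound 1 to compound 3 (0.04 log units; within the scatter). Among these three compounds, a ring nitrogen and a fluoro-bearing ring therefore give matching numbers, and only the chloro compound stands apart. No measurement here explains this result. Still open, from the compounds shown here alone, is how an unsubstituted phenyl ring or pyridin-3-yl would read at this carbon, and whether an aminophenyl group would differ from both.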